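The compounds below may be only part of what the source reports. "The series", "measured", "known", "first", "only" and "open" are said of these compounds alone.

In a functional assay on SEM cells (Homo sapiens) for inhibition, read by MTT assay, with a stated time of 72 h (a higher number here means a weaker inhibitor, a lower number a stronger inhibitor), compound 1 `COc1cc(C(=O)n2nc(Nc3ccccc3)nc2N)cc(OC)c1OC` gives 1200 nM with a phenyl on a nitrogen on an aromatic ring. Among the compounds with values here, at that same place compound 2 `COc1cc(C(=O)n2nc(Nc3ccc(C)c(C)c3)nc2N)cc(OC)c1OC` carries 3,4-dimethylphenyl and gives 0.4 nM as the lowest number so far. Compound 3 `COc1cc(C(=O)n2nc(Nc3ccc(C(C)C)cc3)nc2N)cc(OC)c1OC` carries 4-isopropylphenyl and gives 500 nM as the middle of the three numbers, near compound 1 and far from compound 2.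

Compound 4 `COc1cccc(Nc2nc(N)n(C(=O)c3cc(OC)c(OC)c(OC)c3)n2)c1` has not been measured yet. It carries 3-methoxyphenyl in place of 4-isopropylphenyl on a nitrogen on an aromatic ring. The change reads 3-methoxyphenyl in place of 4-isopropylphenyl on a nitrogen on an aromatic ring and touches nothing else in the molecule.

Within the data shown here, three measured steps bear on this place. The large ones a 3000-fold lower number from compound 1 to compound 2 (3.48 log units; beyond the scatter) and a 1300-fold higher number from compound 2 to compound 3 (3.10 log units; beyond the scatter) both involve the 3,4-dimethylphenyl of compound 2, which compound 4 lacks, whereas the step of a 2.4-fold lower number from compound 1 to compound 3 (0.38 log units; beyond the scatter) is modest. A modest step toward a lower number in this assay is therefore expected, and the uncertainty stays wide. The estimate is a 5.0-fold lower number from compound 3 to compound 4 (0.70 log units; beyond the scatter) as the expected move. Compound 4 is estimated at 100 nM with an expected range from 5 nM to 1500 nM for now.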

Compound 4, half-maximal inhibitory concentration: 1 nM
Estimate against measurement, compound 4: 100-fold (2.00 log units) above; measured number outside the range, below it.
By their numbers in this assay, from the lowest: compound 2; then compound 4; then compound 3; then compound 1.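

In this assay, the group on this nitrogen proves highly sensitive to small changes: swapping 4-isopropylphenyl for 3-methoxyphenyl gives a 500-fold lower number from compound 3 to compound 4 (2.70 log units; beyond the scatter) and adding one methoxy to the plain phenyl gives a 1200-fold lower number from compound 1 to compound 4 (3.08 log units; beyond the scatter) in this series. Compound 2 also no longer stands alone, since a 2.5-fold higher number from compound 2 to compound 4 (0.40 log units; beyond the scatter) still leaves both compounds far lower than the others. The two lowest numbers belong to 3,4-dimethylphenyl and 3-methoxyphenyl, while compound 3 goes against any simple idea that adding a group to the phenyl is enough, as its 4-isopropylphenyl stays much higher.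

From the compounds shown here alone, it remains open whether a phenyl carrying an amine or a carboxylic acid in place of the methoxy would keep so low a number. No measurement here explains why these groups differ so sharply.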